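Swapping nitro for chloro on a trimethoxyphenyl triazole

The source may hold more compounds than are shown below. What is called first, only, known or untested is meant among the compounds shown, and "the series" means these compounds.

Measured compounds:
Compound 1 `COc1cc(-n2ncnc2-c2cccc([N+](=O)[O-])c2)cc(OC)c1OC` gives > 10000 nM in a functional assay on A549 cells (Homo sapiens) for antiproliferative activity, read by MTT assay, with a stated time of 72 h; a lower number here means a stronger inhibitor, a higher number a weaker inhibitor.
Compound 2 `COc1cc(-c2ncnn2-c2cccc(N)c2)cc(OC)c1OC` gives > 10000 nM in this assay.
Compound 3 `COc1cc(-c2ncnn2-c2ccc(Cl)c(Cl)c2)cc(OC)c1OC` gives > 10000 nM in this assay.

Each of these three values is a limit of the assay rather than a measured number. Compound 1 therefore stands only at a limit, and the two other values shown are limits as well, so no ranking among the three is possible (the limit of > 10000 nM in this assay, at which 3 of the 3 values shown sit).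

Compound 4 `COc1cc(-n2ncnc2-c2cccc(Cl)c2)cc(OC)c1OC` is the unmeasured partner of compound 1. The change is chloro in place of nitro on an aromatic carbon. Within the data shown here, the one measured step that changes a group on an aromatic ring, a step that the two limits leave unreadable from compound 2 to compound 3, is itself unreadable, since both ends sit at the limit. Among the measured compounds shown here, no measured step therefore tells how large an effect to expect.

With every measured value at the limit, compound 4 is expected to remain weak as well, and the step that the limit leaves unreadable from compound 1 to compound 4 is estimated to be small or none. Compound 4 is estimated at 15000 nM, within 4000 nM to 60000 nM.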

Compound 4, half-maximal inhibitory concentration: > 10000 nM
Compound 4: a limit, no number; the forecaster's own chance of this, stated with the estimate: 80%; the middle value lies beyond the limit too.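

Compound 4 gives > 10000 nM, which is a limit and not a number. Compound 1 also stands at a limit, so the swap of nitro for chloro between compound 1 and compound 4 cannot be read: the limit of > 10000 nM in this assay, at which 4 of the 4 values shown sit. The compounds shown leave open whether any change to the shared core would give a measurable number.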